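A few compounds are considered here, and "the series" means these few. Any claim that something is new, unique, unknown or untested is made for them only; others in the source may bear on it.

Measured so far in a functional assay on KB cells (Homo sapiens) for inhibition, read by sulforhodamine B assay, with a stated time of 48 h; on this read-out higher numbers stand for weaker inhibition of growth and lower numbers for stronger inhibition of growth:

compound 1, `COc1ccc2c(c1)NC(=O)CN2c1nc(Nc2cccc(C#N)c2)nc2ccccc12`: 61.5 nM
compound 2, `COc1ccc2c(c1)NC(=O)CN2c1nc(NCCCO)nc2ccccc12`: 4.92 nM
compound 3, `COc1ccc2c(c1)NC(=O)CN2c1nc(NC2CCCC2)nc2ccccc12`: 6.92 nM

Compound 2 gives the lowest of the three numbers, but its gap to compound 3 is within the scatter a 1.4-fold higher number from compound 2 to compound 3 (0.15 log units; within the scatter), so the two cannot be ordered; only compound 1 stands apart, and the step of a 13-fold lower number from compound 1 to compound 2 (1.10 log units; beyond the scatter) is large. The cyclopentyl analogue shows the same picture against compound 1, an 8.9-fold lower number from compound 1 to compound 3 (0.95 log units; beyond the scatter).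

Compound 4 is `COc1ccc2c(c1)NC(=O)CN2c1nc(Nc2ccc(C#N)cc2)nc2ccccc12`. The change from compound 2 is 4-cyanophenyl in place of 3-hydroxypropyl on a nitrogen on an aromatic ring. Within the data shown here, this is essentially the reversal of the step from compound 1 to compound 2, with 4-cyanophenyl in place of the 3-cyanophenyl of compound 1; no measured pair separates those two groups, so their difference is unknown. Among the measured compounds shown here, the steps that bear on it are a 13-fold lower number from compound 1 to compound 2 (1.10 log units; beyond the scatter) and an 8.9-fold lower number from compound 1 to compound 3 (0.95 log units; beyond the scatter), both beyond the scatter and both pointing the same way: the aryl amine gave the higher number. A large rise is therefore expected in this assay, with compound 4 expected to land near compound 1 because compound 1 gives 61.5 nM. Compound 4 is estimated at 50 nM, range 15 nM to 200 nM, an expected step of a 10-fold higher number from compound 2 to compound 4 (1.01 log units; beyond the scatter).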

Compound 4, concentration for 50% growth inhibition: 5.39 nM
Beside the measured number, compound 4's estimate is 9.3-fold (0.97 log units) above it, and the stated range ends above it.
By their numbers in this assay, from the lowest: compounds 2, 4 and 3 (each within the scatter of the next); then compound 1.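

In this assay, an aromatic ring on this nitrogen does not by itself go with the higher number: 3-hydroxypropyl, cyclopentyl and 4-cyanophenyl show no readable difference here, a 1.1-fold higher number from compound 2 to compound 4 (0.04 log units; within the scatter) and a 1.3-fold lower number from compound 3 to compound 4 (0.11 log units; within the scatter). Compound 1 alone stands apart, and the sharpest contrast in the series is now between two cyanophenyl groups that differ only in the numbering of the nitrile, an 11-fold lower number from compound 1 to compound 4 (1.06 log units; beyond the scatter), so among these compounds the placing of the nitrile on the phenyl ring, and not the presence of that ring, tracks the difference. Nothing measured here speaks to the origin of this gap between 3-cyanophenyl and 4-cyanophenyl.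

From the compounds shown here alone, whether the high number of compound 1 belongs to the nitrile itself or to any group placed as in 3-cyanophenyl stays open, and unsubstituted phenyl, 3-methoxyphenyl or 3-fluorophenyl on the same nitrogen would separate these readings. Also open, going by these compounds, is whether the hydroxyl of the 3-hydroxypropyl chain matters at all, which plain propyl, or a longer chain ending in an amine or a carboxylic acid, would test.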